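A few compounds are considered here, and "the series" means these few. Any claim that something is new, unique, unknown or untested is made for them only; others in the source may bear on it.

Measured compounds:
- Compound 1, `NC1=C(Cl)C(=O)c2ncccc2C1=O`: 3260 nM in a functional assay on HL-60 cells (Homo sapiens) for antiproliferative activity, read by MTT assay, with a stated time of 48 h; a lower number here means a stronger inhibitor, a higher number a weaker inhibitor
- Compound 2, `CNC1=C([S+](C)[O-])C(=O)c2ncccc2C1=O`: 12100 nM in this assay

Of the two numbers in this assay, compound 2 has the higher one, and its gap to compound 1 lies beyond the usual scatter, so compound 2 is the weaker inhibitor of the pair. Compound 3, `C[S+]([O-])C1=C(N)C(=O)c2cccnc2C1=O`, has not yet been measured. It differs from compound 2 in one place: hydrogen in place of methyl on an amine nitrogen. Among the measured compounds shown here, no measured pair shows this exact change, so there is no step to lean on. Compound 1 also carries a free amine and gives the lower number, which only loosely suggests that removing the methyl could pull the number down. The expected step of a 1.7-fold lower number from compound 2 to compound 3 (0.24 log units; within the scatter) is therefore modest, toward a lower number, though a result within the scatter would not surprise. For compound 3 the estimate in this assay is 7000 nM, with a range from 2500 nM to 20000 nM.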

Compound 3, half-maximal inhibitory concentration: 1300 nM
The estimate for compound 3 lay 5.4-fold (0.73 log units) above the measured number; the measured number lies below the stated range.
By their numbers in this assay, from the lowest: compound 3; then compound 1; then compound 2.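

In this assay, the change from methylamino to amino on the double-bonded ring carbon now has a measured size (a 9.3-fold lower number from compound 2 to compound 3 (0.97 log units; beyond the scatter)), which lies beyond the scatter, so losing a single methyl from this amine nitrogen is enough to lower the number markedly. With the free amino group kept, the methylsulfinyl group in place of chlorine also gives a lower number (a 2.5-fold lower number from compound 1 to compound 3 (0.40 log units; beyond the scatter)), again beyond the scatter, so at this position chlorine is not needed for the lower number. Nothing measured here explains either step.

From the compounds shown here alone, it remains open how a longer chain such as ethyl on the amine nitrogen would compare with methyl and hydrogen. The same question stands for other groups on the sulfur-bearing carbon, such as a nitrile or a carboxylic acid.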